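Adding a Second Chlorine to the Purine Core

The compounds below may be only part of what the source reports. "The series", "measured", "known", "first", "only" and "open" are said of these compounds alone.

Of the compounds shown here, three of this small series have been tested in a functional assay on 786-0 cells (Homo sapiens) for cytotoxicity, read by sulforhodamine B assay, with a stated time of 48 h; a lower number here means that less compound is tolerated, a higher number that more compound is tolerated. Compound 1 `ClCc1ccc(Cn2cnc3c(Cl)ncnc32)cc1` gives 21400 nM in this assay . Compound 3 `ClCc1ccccc1Cn1cnc2nc(Cl)nc(Cl)c21`, which carries two chloro groups on its fused core, gives 30900 nM, a gap from compound 1 that the usual scatter of repeated measurements covers, so the two cannot be ranked. Compound 2 `Nc1nc(Cl)c2ncn(Cc3ccccc3CCl)c2n1`, with an amino group in place of one chloro, reaches only the upper limit of this assay , > 100000 nM; this is a limit, not a number (the limit of > 100000 nM in this assay, at which 1 of the 3 values shown sits).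

The step from compound 1 to compound 4 `ClCc1ccc(Cn2cnc3c(Cl)nc(Cl)nc32)cc1` is a single change: chloro in place of hydrogen on an aromatic carbon. Among the measured compounds shown here, no directly comparable measured pair shows what this change does, so the expectation rests on compound 1 at 21400 nM and compound 3 at 30900 nM, which together suggest no shift beyond the scatter. Compound 4 is therefore expected to give about 25000 nM, within 10000 nM to 60000 nM, meaning an expected step of a 1.2-fold higher number from compound 1 to compound 4 (0.07 log units; within the scatter).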

Compound 4, concentration lethal to 50% of the cells: 61700 nM
Compound 4: the middle estimate sits 2.5-fold (0.39 log units) below what was measured; the whole stated range lies below it.
By their numbers in this assay, from the lowest: compounds 1, 3 and 4 (each within the scatter of the next, the first and the last beyond it). At a limit, above all of these: compound 2.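

On the shared core, a chloro on the aromatic carbon between two ring nitrogen atoms gives a 2.9-fold higher number from compound 1 to compound 4 (0.46 log units; beyond the scatter) in this assay, so more compound is tolerated and this position responds to the change. Among the compounds shown here, the earlier compounds differ from each other in more than one place, which makes this the first direct reading of the chloro group here, though it rests on a single pair. Nothing in the data explains why the number moves.

Going by these compounds, it remains open whether a methyl group, a methoxy group or a nitrile on this same carbon would move the number in the same direction or as far. One step also cannot tell whether the effect is particular to chloro or would follow from any group placed there.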